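A few compounds are considered here, and "the series" means these few. Any claim that something is new, unique, unknown or untested is made for them only; others in the source may bear on it.

Measured compounds:
compound 1 `CC1=C(C(=O)OC(C)(C)C)C(c2cccs2)NC(=S)N1`: 22%
compound 2 `CC1=C(C(=O)OC(C)(C)C)C(c2ccsc2)NC(=S)N1`: 16%
compound 3 `COC(=O)C1=C(C)N(C)C(=O)NC1c1cccs1`: 30%

All three were tested in an assay on membranes from CHO cells for displacement of a labelled ligand from adenosine receptor A1 (Homo sapiens), read by scintillation counting, with a stated time of 60 min, tested at 1 uM; on this read-out higher numbers stand for more inhibition at the one concentration tested (going by the name of the read-out) and lower numbers for less inhibition. Compound 1 and compound 2 differ by one change, (thiophen-3-yl in place of thiophen-2-yl on a saturated ring carbon), which made a step of a number 6 percentage points lower from compound 1 to compound 2 (within the scatter). Compound 3 differs from compound 1 in more than one place, and the difference between the two cores is not broken down here; compound 3 has the highest of the three numbers, yet its gap to compound 1 lies within the scatter and only its gap to compound 2 lies beyond it.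

Compound 4 `COC(=O)C1=C(C)N(C)C(=O)NC1c1ccsc1` is not yet measured. It carries the same kind of change as compound 2 does, (thiophen-3-yl in place of thiophen-2-yl on a saturated ring carbon), but around the place the cores differ: in compound 3 the site is next to the ring atom that bears a methoxycarbonyl group, whereas in compound 1 that ring atom bears a group of 7 heavy atoms. For compound 4 a step of a number 6 percentage points lower from compound 3 to compound 4 (within the scatter) is expected, resting on the small step from compound 1 to compound 2, a number 6 percentage points lower from compound 1 to compound 2 (within the scatter). Compound 4 is therefore estimated at 24%, between 10% and 38%.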

Compound 4, a percentage reported as inhibition, at one concentration (the size of the read-out at that concentration, not a potency): 24%
Compound 4: the middle estimate sits on the measured number at the digits printed; the range from low to high includes it.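

In this assay, thiophen-3-yl in place of thiophen-2-yl gave a number 6 percentage points lower from compound 3 to compound 4 (within the scatter), and this step can be set beside the earlier one: the same change on two cores in this assay, a number 6 percentage points lower (within the scatter) from compound 1 to compound 2 and a number 6 percentage points lower (within the scatter) from compound 3 to compound 4, 0 percentage points apart, within the scatter of two such steps Across these two pairs, then, the change carried from the core of compound 1 to the core of compound 3 with a step of the same size. Each step lies within the scatter, however, so the pairs do not show that the change moves the number at all, and two pairs set no rule for other cores.

The compounds shown leave open how a phenyl or furan-2-yl group on that saturated ring carbon would read. They also leave open what a carboxylic acid or a longer chain would do in place of the methoxycarbonyl group.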